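From methoxy to methyl on an aromatic carbon

The source may hold more compounds than are shown below. What is called first, only, known or untested is meant among the compounds shown, and "the series" means these compounds.

Measured in a functional assay on MCF7 cells (Homo sapiens) for cytotoxicity, read by MTT assay, with a stated time of 72 h; a lower number here means a stronger inhibitor, a higher number a weaker inhibitor:
- Compound 1 `CNC(=O)c1cc(Oc2ccc(NC(=O)c3nccc(-c4ccc([N+](=O)[O-])cc4)n3)cc2)ccn1`: > 100000 nM (a limit)
- Compound 2 `CNC(=O)c1cc(Oc2ccc(NC(=O)c3nccc(-c4ccc(OC)cc4)n3)cc2)ccn1`: 35200 nM

Compound 1 stands at > 100000 nM, which is a limit of the assay and not a number. Among the measured compounds shown here, compound 2 , at 35200 nM, therefore holds the only true number in this assay. Compound 3 `CNC(=O)c1cc(Oc2ccc(NC(=O)c3nccc(-c4ccc(C)cc4)n3)cc2)ccn1` has not yet been measured. It differs from compound 2 as follows: methyl in place of methoxy on an aromatic carbon. This places methyl in place of methoxy on an aromatic carbon.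

For the measured compounds named here, one measured step bears on this carbon: an at least 2.8-fold lower number from compound 1 to compound 2 (0.45 log units; beyond the scatter), with methoxy in place of nitro. Its size is only a bound because of the limit of > 100000 nM in this assay, at which 1 of the 2 values shown sits. That single step gives no firm direction for methyl, so no step beyond the scatter is expected in this assay. The expected size is a 1.1-fold higher number from compound 2 to compound 3 (0.06 log units; within the scatter). For compound 3 the estimated value is 40000 nM, with an expected range from 15000 nM to 100000 nM.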

Compound 3, half-maximal inhibitory concentration: 44300 nM
For compound 3 the middle estimate is 1.1-fold (0.04 log units) below the measured one, and the stated range covers the measured number.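

In this assay, the change from 4-methoxyphenyl to 4-methylphenyl gives a 1.3-fold higher number from compound 2 to compound 3 (0.10 log units; within the scatter), so methoxy and methyl on this aromatic carbon cannot be told apart, even though methyl has one heavy atom and no hydrogen-bond acceptor where methoxy has two heavy atoms and one acceptor. Replacing nitro with methyl gives an at least 2.2-fold lower number from compound 1 to compound 3 (0.35 log units; beyond the scatter), so a second group at this carbon now stands beyond the scatter from nitro. Compound 1 sits at a limit of the assay and not a number, so the size of that step is only a bound: the limit of > 100000 nM in this assay, at which 1 of the 3 values shown sits.

The compounds shown leave open whether an amine or a chlorine atom on this carbon would read like methoxy and methyl or like nitro. They also leave open whether a longer chain here, such as butyl, would keep the number of compound 3.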